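Solubility notes on a shared amide core

The compounds below may be only part of what the source reports. "The series", "measured", "known", "first", "only" and "open" are said of these compounds alone.

Measured so far:
- compound 1, `CNC(=O)c1cc(C(=O)NC2CCC2)cn(Cc2ccncc2)c1=O`: >= 118 ug/mL
- compound 2, `CNC(=O)c1cc(C(=O)NC2CC2)cn(Cc2cccc(OC)c2)c1=O`: 79 ug/mL

Compound 1 stands at a limit of a physicochemical assay for solubility; on this read-out higher numbers stand for higher solubility and lower numbers for lower solubility: its value of >= 118 ug/mL is not a number but the edge of what the assay reports, as the limit of >= 118 ug/mL in this assay, at which 1 of the 2 values shown sits, records. Compound 2 gives 79 ug/mL in this assay. Among the measured compounds shown here, the two differ in more than one place, so no single step connects them; their two values are all that can be said of the pair.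

Compound 3, `CNC(=O)c1cc(C(=O)NC2CCC2)cn(Cc2cccc(NC)c2)c1=O`, is the next member and has not been measured in this assay. Against compound 1 the change is 3-(methylamino)phenyl in place of pyridin-4-yl on a saturated chain carbon bound to an aromatic nitrogen. For the measured compounds named here, no measured step of the same kind is available, so the size of the step has to be guessed.

The expectation is a drop beyond the usual scatter, giving a step of an at least 2.9-fold lower number from compound 1 to compound 3 (0.46 log units; beyond the scatter) in this assay. On that basis compound 3 is estimated at 40 ug/mL, with a plausible range from 15 ug/mL to 110 ug/mL.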

Compound 3, solubility: >= 155 ug/mL
Compound 3 gave a limit, no number; the forecaster's own chance of this, stated with the estimate: 15%; middle value at least 3.8-fold (0.58 log units) from the limit.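

Among the compounds shown here, compound 1 and compound 3 both stand at limits rather than numbers in this assay, and no step between them can be read. The compounds shown leave open whether 3-(methylamino)phenyl in place of pyridin-4-yl on a saturated chain carbon bound to an aromatic nitrogen changes the read-out at all, and by how much.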